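One group exchanged on the shared core of compound 3

A few compounds are considered here, and "the series" means these few. Any claim that something is new, unique, unknown or untested is made for them only; others in the source may bear on it.

Compound 1 `CC(=O)Nc1ccc(S(=O)(=O)N2C/C(=C\c3ccc(C#N)cc3)C(=O)/C(=C/c3ccc(C#N)cc3)C2)cc1`: 7120 nM
Compound 2 `COc1cc(/C=C2\CN(S(=O)(=O)c3ccc(F)cc3)C/C(=C\c3ccc(C#N)cc3)C2=O)cc(OC)c1OC`: 4120 nM
Compound 3 `CC(=O)Nc1ccc(S(=O)(=O)N2C/C(=C\c3ccc(C#N)cc3)C(=O)/C(=C/c3ccccc3F)C2)cc1`: 3150 nM

In a functional assay on SMMC-7721 cells (Homo sapiens) for cytotoxicity, read by MTT assay, with a stated time of 24 h (a higher number here means a weaker inhibitor, a lower number a stronger inhibitor), compound 3 gives 3150 nM. Among the measured compounds shown here, this value lies within the usual scatter of the one for compound 2, while compound 1 lies beyond the scatter from it. The next compound to be tested, compound 4 `COc1cc(/C=C2\CN(S(=O)(=O)c3ccc(NC(C)=O)cc3)C/C(=C\c3ccc(C#N)cc3)C2=O)cc(OC)c1OC`, differs from compound 3 in a single place: 3,4,5-trimethoxyphenyl in place of 2-fluorophenyl on a double-bonded chain carbon bound to a double-bonded ring carbon.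

For the measured compounds named here, one measured step bears directly on this place. It put 2-fluorophenyl in place of 4-cyanophenyl and was modest: a 2.3-fold lower number from compound 1 to compound 3 (0.35 log units; beyond the scatter). That step does not involve the incoming group, however. Compound 2 does carry the 3,4,5-trimethoxyphenyl and gives 4120 nM, but it differs from compound 4 elsewhere in the structure. Going by the values given here, no measured pair compares the 3,4,5-trimethoxyphenyl directly with another group at this place. Among the compounds with values here, the value of compound 2 and the modest size of the one measured step give no ground for expecting a change beyond the scatter in either direction. The expected step is a 1.2-fold higher number from compound 3 to compound 4 (0.08 log units; within the scatter). In this assay, the estimated value for compound 4 is 3800 nM, with an expected range from 1700 nM to 8500 nM.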

Compound 4, half-maximal inhibitory concentration: 1730 nM
Estimate against measurement, compound 4: 2.2-fold (0.34 log units) above, within the range that was stated.
By their numbers in this assay, from the lowest: compounds 4, 3, 2 and 1 (each within the scatter of the next, the first and the last beyond it).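

In this assay the 3,4,5-trimethoxyphenyl can now be compared directly with other groups on the double-bonded chain carbon: exchanging 2-fluorophenyl for it gives a 1.8-fold lower number from compound 3 to compound 4 (0.26 log units; within the scatter) and does not separate the two groups, whereas exchanging 4-cyanophenyl for it gives a 4.1-fold lower number from compound 1 to compound 4 (0.61 log units; beyond the scatter) and is a modest step that clears the scatter. Read with a 2.3-fold lower number from compound 1 to compound 3 (0.35 log units; beyond the scatter) as well, this sets 4-cyanophenyl apart from the other two groups at this place, in a series of only three groups there. Compound 4 also shows that the place is not the only one that matters, since acetamido in place of fluoro on an aromatic carbon gives a 2.4-fold lower number from compound 2 to compound 4 (0.38 log units; beyond the scatter), a modest step resting on this single pair.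

On these data alone, it remains open whether an amine or a carboxylic acid on the aromatic ring at this place would separate from 2-fluorophenyl and 3,4,5-trimethoxyphenyl, and whether the acetamido step would recur with 2-fluorophenyl or 4-cyanophenyl at the chain carbon. Nothing shown here offers an explanation for any of these differences.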